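A Chloro Step on a Shared Core

The compounds below may be only part of what the source reports. "The series", "measured", "known", "first", "only" and "open" are said of these compounds alone.

Compound 1 `Cc1ccc2nc(/N=C3\C(=O)N(CN(C)C)c4cccc(Cl)c43)sc2c1` gives 20700 nM in a functional assay on MCF7 cells (Homo sapiens) for cytotoxicity, read by sulforhodamine B assay, with a stated time of 48 h; on this read-out higher numbers stand for weaker inhibition of growth and lower numbers for stronger inhibition of growth.
Compound 2 `Cc1ccc2nc(/N=C3\C(=O)N(CN4CCCCC4)c4cccc(Cl)c43)sc2c1` gives 30900 nM in this assay.
Compound 3 `CCN(CC)CN1C(=O)/C(=N\c2nc3ccc(C)cc3s2)c2ccccc21` gives 74800 nM in this assay.

Compound 3 stands at the highest number of the three, beyond the scatter from both compound 2 and compound 1. For the measured compounds named here, the one measured step, a 1.5-fold higher number from compound 1 to compound 2 (0.17 log units; within the scatter), concerns the amine on the chain and says nothing about a chloro. Compound 4 `CCN(CC)CN1C(=O)/C(=N\c2nc3ccc(C)cc3s2)c2c(Cl)cccc21` differs from compound 3 by chloro in place of hydrogen on an aromatic carbon. Compound 1 and compound 2, which carry that chloro, give lower numbers than compound 3, but they also differ in their amine, so the data give no clean reading of the chloro alone. Compound 4 is therefore expected to show a 2.1-fold lower number from compound 3 to compound 4 (0.33 log units; beyond the scatter), toward a lower number, with wide uncertainty. The estimate for compound 4 is 35000 nM, between 15000 nM and 80000 nM.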

Compound 4, concentration for 50% growth inhibition: 19200 nM
Beside the measured number, compound 4's estimate is 1.8-fold (0.26 log units) above it; measured number inside the range.
By their numbers in this assay, from the lowest: compounds 4, 1 and 2 (each within the scatter of the next); then compound 3.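

For the compounds shown here, with diethylamino held fixed, chloro in place of hydrogen on an aromatic carbon gives a 3.9-fold lower number from compound 3 to compound 4 (0.59 log units; beyond the scatter) in this assay and so provides the one clean reading of this change. Among the compounds carrying the chloro, the amine on the chain makes no difference beyond the scatter, with a 1.6-fold lower number from compound 2 to compound 4 (0.21 log units; within the scatter) and a 1.1-fold lower number from compound 1 to compound 4 (0.03 log units; within the scatter) both small. Nothing available explains either result.

On these data alone, whether fluoro, bromo or methoxy at this aromatic carbon would give a similar step remains open. Also open, as far as these compounds go, is how dimethylamino or piperidin-1-yl would read on the core without the chloro.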